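This account rests on a few compounds, and the source may have more. Where it says the series, first, only, none or still open, it means among the compounds named here.

Measured so far:

Compound 1, `COc1cccc(-c2cc(=O)c3cc(NC(C)=O)ccc3o2)c1`: in an ADME assay on MT4 cells (Homo sapiens) for cytotoxicity, read by MTT assay, with a stated time of 4 days (a higher number here means that more compound is tolerated, a lower number that less compound is tolerated), compound 1 gives > 404000 nM, which is a limit of the assay rather than a number.
Compound 2, `COc1cccc(-c2oc3ccc(NC(C)=O)cc3c(=O)c2OC)c1`: in this assay compound 2 gives 369000 nM.
Compound 3, `COc1c(-c2ccccc2)oc2ccc(N)cc2c1=O`: in this assay compound 3 gives 126000 nM.

The change from compound 1 to compound 2 is methoxy in place of hydrogen on an aromatic carbon. The step it made was an at least 1.0-fold lower number from compound 1 to compound 2 (0.03 log units; that floor lies within the scatter), and the reading for compound 1 is one of the values that sit at the limit of > 404000 nM in this assay, at which 1 of the 3 values shown sits, so only a floor for the step can be given. Compound 3 has the lowest number of the two compounds with a number, standing beyond the scatter from compound 2; how the core of compound 3 differs from the core of compound 1 is not broken down here.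

Compound 4, `COc1ccc(-c2oc3ccc(N)cc3c(=O)c2OC)cc1`, is not yet measured. It differs from compound 3 by methoxy in place of hydrogen on an aromatic carbon. Among the compounds with values here, this is the same kind of change as the one from compound 1 to compound 2, not the same: there the methoxy entered on a six-membered aromatic ring with one oxygen, part of a fused or bridged system of two rings, ortho to a 3-methoxyphenyl group, whereas here it enters a six-membered aromatic ring of carbon only, para to a large group. Because the earlier step of an at least 1.0-fold lower number from compound 1 to compound 2 (0.03 log units; that floor lies within the scatter) stayed within the scatter, the expected step here is a 1.0-fold higher number from compound 3 to compound 4 (0.01 log units; within the scatter). Compound 4 is therefore estimated at 130000 nM in this assay, with a likely range from 60000 nM to 280000 nM.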

Compound 4, half-maximal cytotoxic concentration: 200000 nM
Compound 4: middle estimate off by 1.5-fold (0.19 log units), on the low side, within the range that was stated.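

In this assay, putting methoxy in place of hydrogen on an aromatic carbon, para to a large group, gives a 1.6-fold higher number from compound 3 to compound 4 (0.20 log units; within the scatter), so on this core the change cannot be told apart from repeat measurements. This does not show that the change carries over unaltered from one core to the other, and it does not show that the two cores respond differently: the same change on two cores in this assay, an at least 1.0-fold lower number (0.03 log units; that floor lies within the scatter) from compound 1 to compound 2 and a 1.6-fold higher number (0.20 log units; within the scatter) from compound 3 to compound 4; the limit leaves it open whether they differ. The reading of compound 1 is a limit of the assay and not a number: the limit of > 404000 nM in this assay, at which 1 of the 4 values shown sits.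

The compounds shown leave open how a group other than methoxy, such as a fluorine atom, a hydroxyl or a longer chain like ethoxy, would read on the six-membered aromatic ring of carbon only. They also leave open whether methoxy would still stay within the scatter on a core that carries a carboxylic acid where compound 3 carries its amine.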